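From Methyl to Phenyl: Compound 2 to Compound 3

The compounds below may be only part of what the source reports. "The series", "measured", "known", "first", "only" and "open" are said of these compounds alone.

Of the compounds shown here, two have so far been measured in an assay on mitochondria for inhibition of Amine oxidase [flavin-containing] B (Bos taurus); a higher number here means a weaker inhibitor, a lower number a stronger inhibitor. Compound 1 `Clc1ccc(/C=N/Nc2nc(-c3ccccc3)cs2)c(Cl)c1` gives 132 nM. Compound 2 `Cc1ccc(/C=N/c2nc(C)cs2)cc1` gives 832 nM, the higher of the two numbers, and its gap to compound 1 lies beyond the usual scatter, so compound 2 is the weaker inhibitor of the pair. The two structures differ in several places at once, so no single change can be read from that gap.

Compound 3 `Cc1ccc(/C=N/c2nc(-c3ccccc3)cs2)cc1` follows from compound 2 by one change: phenyl in place of methyl on an aromatic carbon. Compound 1 also carries a phenyl at this place and sits at the lower number, yet it differs from compound 2 elsewhere too, so that comparison is only a loose hint. For the measured compounds named here, no measured step isolates this change. The expected step in this assay is a 2.8-fold lower number from compound 2 to compound 3 (0.44 log units; beyond the scatter), a moderate drop in the number, beyond the scatter but short of the gap to compound 1. Compound 3 is therefore estimated at 300 nM in this assay, with a range from 80 nM to 1100 nM.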

Compound 3, inhibition constant: 0.813 nM
Compound 3: the middle estimate sits 370-fold (2.57 log units) above what was measured, outside the stated range (below it).
By their numbers in this assay, from the lowest: compound 3; then compound 1; then compound 2.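

Phenyl in place of methyl on this aromatic carbon, next to the ring nitrogen, gives a 1000-fold lower number from compound 2 to compound 3 (3.01 log units; beyond the scatter) in this assay, so this one place alone can move the number by a large step. For the compounds shown here, the earlier gap between compound 1 and compound 2 could not be assigned to any single change, whereas here only this group differs between the two compounds. Going by these compounds alone, the change adds a six-membered aromatic ring of carbon only and no hydrogen-bond donor, hydrogen-bond acceptor or net charge, but nothing measured so far gives a reason for a step of this size.

The compounds shown cover only methyl and phenyl at this place, so it remains open whether the step requires an aromatic ring, or whether a saturated cyclohexyl ring or a longer chain such as butyl would give a similar number. As far as these compounds go, it is also open whether a substituent on the new phenyl ring, such as an amine or a carboxylic acid, would keep the number low or raise it again.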